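A few compounds are considered here, and "the series" means these few. Any claim that something is new, unique, unknown or untested is made for them only; others in the source may bear on it.

Compound 1 `C[C@@H]1O[C@@H](N2C(=O)/C(=C3\Nc4ccccc4C3=O)c3ccccc32)[C@H](O)[C@H](O)[C@H]1O` was examined in a functional assay on 5637 cells (Homo sapiens) for antiproliferative activity, read by crystal violet staining, with a stated time of 96 h; a higher number here means a weaker inhibitor, a lower number a stronger inhibitor. In this assay compound 1 gives only a limit, > 25000 nM, which is the limit of > 25000 nM in this assay, at which 1 of the 3 values shown sits. Compound 2 `C[C@@H]1O[C@H](N2C(=O)/C(=C3\Nc4ccccc4\C3=N/O)c3ccccc32)[C@H](O)[C@H](O)[C@H]1O` gives 15500 nM in this assay. Compound 3 `Cc1cc(C)c2c(c1)N([C@H]1O[C@@H](C)[C@H](O)[C@@H](O)[C@H]1O)C(=O)/C2=C1\Nc2ccccc2C1=O` also gives only a limit in this assay, > 12500 nM, which is the limit of > 12500 nM in this assay, at which 1 of the 3 values shown sits. Within the data shown here, none of these three compounds differs from another in a single place, so no measured step connects them, and compound 1 stands at a limit rather than at a number. Compound 4 `C[C@@H]1O[C@@H](N2C(=O)/C(=C3\Nc4ccc(Cl)cc4C3=O)c3ccccc32)[C@H](O)[C@H](O)[C@H]1O` differs from compound 1 by chloro in place of hydrogen on an aromatic carbon. Among the measured compounds shown here, with no measured step to lean on, the step of a number no higher from compound 1 to compound 4 (the limit leaves the size open) is expected to stay within the usual scatter. Compound 4 is therefore estimated at 25000 nM, with a range from 8000 nM to 60000 nM.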

Compound 4, half-maximal inhibitory concentration: 12900 nM
The estimate for compound 4 lay 1.9-fold (0.29 log units) above the measured number; the range from low to high includes it.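

In this assay, among these compounds, chloro in place of hydrogen on an aromatic carbon gives an at least 1.9-fold lower number from compound 1 to compound 4 (0.28 log units; that floor lies within the scatter), the first step in this set that can be read, and it shows that this carbon carries a substituent with compound 4 still giving a measured number. The size is only a floor, and how far it truly reaches stays unknown, because compound 1 stands at a limit: the limit of > 25000 nM in this assay, at which 1 of the 4 values shown sits.

As far as these compounds go, whether an amine, a methoxy group or a carboxylic acid on this carbon would give a different number remains open. So does whether chloro would act alike on another aromatic carbon of the shared core.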